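A few compounds are considered here, and "the series" means these few. Any claim that something is new, unique, unknown or untested is made for them only; others in the source may bear on it.

Compound 1 `O=C(O)/C(S)=C/c1c[nH]c2cc(F)ccc12` and compound 2 `O=C(O)/C(S)=C/c1c[nH]c2cccc(F)c12` share a core, and both carry a thiol and a carboxylic acid. In an assay on isolated protein for inhibition of Calpain-1 catalytic subunit (Sus scrofa) (a higher number here means a weaker inhibitor, a lower number a stronger inhibitor), compound 1 gives 300 nM, and compound 2 gives 300 nM; these two numbers lie within the usual scatter of each other. Among the measured compounds shown here, compound 3 `O=C(O)/C(S)=C/c1ccccc1Br` keeps the thiol and the acid but attaches them to a six-membered aromatic ring of carbon only that bears a bromo group. In this assay compound 3 gives 9100 nM, the highest of the three numbers, and its distance from compound 1 and from compound 2 lies well beyond the scatter. Compound 4 `O=C(O)/C(S)=C/c1ccccc1F` has not been measured. It differs from compound 3 by fluoro in place of bromo on an aromatic carbon, ortho to a group of 6 heavy atoms. For the measured compounds named here, no measured pair differs in just this way, so there is no step to lean on. The step of a 1.1-fold higher number from compound 3 to compound 4 (0.04 log units; within the scatter) is therefore estimated to be small, with no clear direction beyond the scatter. Compound 4 is expected to give about 10000 nM in this assay, within a range from 3000 nM to 35000 nM.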

Compound 4, half-maximal inhibitory concentration: 23200 nM
For compound 4 the middle estimate is 2.3-fold (0.37 log units) below the measured one; the measured number falls inside the stated range.
By their numbers in this assay, from the lowest: compounds 1 and 2 (each within the scatter of the next); then compound 3; then compound 4.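

In this assay, fluoro in place of bromo on an aromatic carbon, ortho to a group of 6 heavy atoms, gives a 2.5-fold higher number from compound 3 to compound 4 (0.41 log units; beyond the scatter) and so does not leave the inhibitor unchanged. Among the compounds shown here, this is the only pair here that differs in one place, and it shows that the choice of group at this position affects the number, even though both groups are single atoms with no hydrogen-bond donors or acceptors and no net charge. Nothing in the available data accounts for this step.

Going by these compounds, whether a plain hydrogen, a chloro group or a methoxy group at this position would give a lower or a higher number remains open. One pair also cannot show whether the same exchange would give a similar step at another carbon of the ring or on the core of compound 1.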